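A Hydroxyphenyl Swap at an Amide-Type Nitrogen

The source may hold more compounds than are shown below. What is called first, only, known or untested is meant among the compounds shown, and "the series" means these compounds.

Measured in a functional assay on L1210 cells (Mus musculus) for inhibition, read by MTT assay, with a stated time of 72 h; on this read-out lower numbers stand for stronger inhibition and higher numbers for weaker inhibition
compound 1 `COc1cc(NC(C)CCCNC(=O)Nc2cccc(O)c2)c2ncccc2c1` gives 25000 nM
compound 2 `COc1cc(NC(C)CCCNC(=O)NNC(=O)Nc2cccc(Cl)c2)c2ncccc2c1` gives 27000 nM

Compound 2 sits level with compound 1, within the usual scatter of repeated measurements. Compound 3 `COc1cc(NC(C)CCCNC(=O)Nc2ccc(O)cc2)c2ncccc2c1` is still unmeasured. It carries 4-hydroxyphenyl in place of ((3-chlorophenyl)carbamoyl)amino on an amide-type nitrogen, and the change in detail is 4-hydroxyphenyl in place of ((3-chlorophenyl)carbamoyl)amino on an amide-type nitrogen with the rest of the molecule untouched. Among the compounds with values here, the only measured step at that place is a 1.1-fold higher number from compound 1 to compound 2 (0.03 log units; within the scatter) and it is small. On that single step, the estimated change in this assay is a 1.1-fold lower number from compound 2 to compound 3 (0.03 log units; within the scatter) and nothing beyond the scatter is expected. For compound 3 the estimate is 25000 nM with an expected range from 11000 nM to 55000 nM in all.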

Compound 3, half-maximal inhibitory concentration: 21000 nM
Compound 3: the middle estimate sits 1.2-fold (0.08 log units) above what was measured; measured number inside the range.
By their numbers in this assay, from the lowest: compounds 3, 1 and 2 (each within the scatter of the next).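

In this assay, 4-hydroxyphenyl in place of 3-hydroxyphenyl on the amide-type nitrogen gives a 1.2-fold lower number from compound 1 to compound 3 (0.08 log units; within the scatter) and 4-hydroxyphenyl in place of ((3-chlorophenyl)carbamoyl)amino gives a 1.3-fold lower number from compound 2 to compound 3 (0.11 log units; within the scatter). Both steps stay within the scatter, so the three groups at this place cannot be told apart in this assay, even with the hydroxyl placed differently on the phenyl ring. No measurement shown here offers an explanation for this flat result.

Still open, as far as these compounds go, is whether an amine or a carboxylic acid at this nitrogen would move the number beyond the scatter.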